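The source may hold more compounds than are shown below. What is called first, only, known or untested is meant among the compounds shown, and "the series" means these compounds.

Measured so far in a functional assay for inhibition, with Sus scrofa as the target; a higher number here means a weaker inhibitor, a lower number a stronger inhibitor:
compound 1 `CC1(C)Oc2ccc(C#N)cc2[C@@H](Oc2ccccn2)[C@]1(C)O`: 6000 nM
compound 2 `CC1(C)Oc2ccc(C#N)cc2[C@@H](On2ccccc2=O)[C@]1(C)O`: > 100000 nM
compound 3 `CC1(C)Oc2ccc(C#N)cc2[C@@H](Nn2ccccc2=O)[C@]1(C)O`: not yet measured

Compound 2 is reported only as a limit of the assay, > 100000 nM, not as a number: the limit of > 100000 nM in this assay, at which 1 of the 2 values shown sits. The next change is a group of 8 heavy atoms (5 carbon, 2 nitrogen, 1 oxygen; one six-membered aromatic ring with 1 hetero atom) in place of a group of 8 heavy atoms (5 carbon, 1 nitrogen, 2 oxygen; one six-membered aromatic ring with 1 hetero atom), on a saturated ring carbon, on a saturated ring carbon, next to the ring atom that bears a hydroxy group. Among the measured compounds shown here, only one measured step bears on it: an at least 16-fold higher number from compound 1 to compound 2 (1.22 log units; beyond the scatter). That step is large and beyond the scatter, but it is a different exchange on the same core, so it gives no direct size for this one. On these data alone, since its end point is a limit, its true size is also open. In this assay a lower number is expected for compound 3, by a moderate but uncertain margin, and a second limit remains possible. For the measured compounds named here, compound 1, at 6000 nM, is the only measured number and serves as the reference.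

The expected step is an at least 5.0-fold lower number from compound 2 to compound 3 (0.69 log units; beyond the scatter).

For compound 3 the estimated value is 20000 nM, with an expected range of 2000 nM to 100000 nM.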

Compound 3, half-maximal inhibitory concentration: > 100000 nM
Compound 3 was reported as a limit; the forecaster's own chance of this, stated with the estimate: 35%; at least 5.0-fold (0.69 log units) between middle value and limit.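

In this assay compound 3 gives > 100000 nM, which is a limit of the assay and not a number. Among the compounds shown here, the one readable step is an at least 16-fold higher number from compound 1 to compound 3 (1.22 log units; beyond the scatter), so on this saturated ring carbon the entering group, with its 1 hydrogen-bond donor, leaves compound 3 on the same side of compound 1 as the group in compound 2, which has 0 hydrogen-bond donors. The step between compound 2 and compound 3 cannot be read, because both compounds sit at the same limit: the limit of > 100000 nM in this assay, at which 2 of the 3 values shown sit.

On these data alone, how far compound 2 and compound 3 each lie past that limit remains open, and with it whether exchanging the oxygen attachment for the nitrogen attachment changes the read-out at all. Also open, as far as these compounds go, is how other groups on this saturated ring carbon, such as a simple amine or a methoxy group, would compare with compound 1 in this assay on the shared core.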